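Cytotoxicity notes: the step from compound 3 to compound 4

The source may hold more compounds than are shown below. What is called first, only, known or untested is meant among the compounds shown, and "the series" means these compounds.

Measured so far in an ADME assay on MT2 cells (Homo sapiens) for cytotoxicity, read by XTT assay, with a stated time of 4 days; on this read-out higher numbers stand for lower toxicity in this test and lower numbers for higher toxicity in this test:
- compound 1 `Cc1cccc2cc(CN(Cc3ccco3)C(=O)c3ccccc3)c(=O)[nH]c12` gives > 67100 nM, a limit of the assay, not a number
- compound 2 `Cc1cccc2cc(CN(Cc3ccco3)C(=O)c3ccccc3F)c(=O)[nH]c12` gives > 64000 nM, likewise a limit
- compound 3 `Cc1ccc2[nH]c(=O)c(CN(Cc3ccco3)C(=O)c3ccc(Cl)cc3)cc2c1` gives > 61400 nM, likewise a limit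

Compound 3 stands at a limit of this assay, (the limit of > 61400 nM in this assay, at which 1 of the 3 values shown sits), so its position on the numbers is only an edge, not a value. The two other measured compounds also sit at limits, the limit of > 64000 nM in this assay, at which 1 of the 3 values shown sits, and (the limit of > 67100 nM in this assay, at which 1 of the 3 values shown sits), so none of the three values is a number. Among the compounds with values here, the one single-point step measured, a step that the two limits leave unreadable from compound 1 to compound 2, cannot be read in size or direction.

Compound 4 `Cc1ccc2[nH]c(=O)c(CN(Cc3ccco3)C(=O)c3ccc(Cl)c(Cl)c3)cc2c1` differs from compound 3 by chloro in place of hydrogen on an aromatic carbon. Within the data shown here, no measured step bears readably on this change: the only available step, a step that the two limits leave unreadable from compound 1 to compound 2, is unreadable, and no chloro-for-hydrogen step has been measured at all. The expectation for compound 4 therefore rests on the three limits alone, and the expected step is an at least 1.0-fold lower number from compound 3 to compound 4 (0.01 log units; that floor lies within the scatter), none beyond the scatter. Compound 4 is estimated at 60000 nM, within 20000 nM to 150000 nM, and is most likely to be reported again only as a limit.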

Compound 4, half-maximal cytotoxic concentration: 70700 nM
Compound 4: middle estimate off by 1.2-fold (0.07 log units), on the low side; the range from low to high includes it.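

The step from compound 3 to compound 4 in this assay cannot be read in size or direction, as compound 3 stands only at a limit of the assay. The compounds shown leave open whether 3,4-dichlorophenyl in place of 4-chlorophenyl changes the half-maximal cytotoxic concentration at all, and in which direction.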